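Removing the ester chain: what to expect

This account rests on a few compounds, and the source may have more. Where it says the series, first, only, none or still open, it means among the compounds named here.

In a functional assay for inhibition (on this read-out lower numbers stand for stronger inhibition and higher numbers for weaker inhibition), three compounds sharing one core have been measured. Compound 1 `CN(C)CCCOc1ccc2c(=O)cc(-c3cc(C(C)(C)C)c(O)c(C(C)(C)C)c3)oc2c1` gives 700 nM, compound 2 `CC(C)(C)c1cc(-c2cc(=O)c3ccccc3o2)cc(C(C)(C)C)c1O` gives 3000 nM, and compound 3 `CCOC(=O)CCCCOc1ccc2c(=O)cc(-c3cc(C(C)(C)C)c(O)c(C(C)(C)C)c3)oc2c1` gives 3000 nM. Compound 3 therefore matches compound 2 at the high end of these three numbers, while compound 1 stands apart from both, as the step of a 4.3-fold higher number from compound 1 to compound 3 (0.63 log units; beyond the scatter) shows.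

Compound 4 `CC(C)(C)c1cc(-c2cc(=O)c3ccc(O)cc3o2)cc(C(C)(C)C)c1O` differs from compound 3 by hydrogen in place of 4-(ethoxycarbonyl)butyl on an oxygen on an aromatic ring. This is hydrogen in place of 4-(ethoxycarbonyl)butyl on an oxygen on an aromatic ring, so that 4-(ethoxycarbonyl)butoxy becomes hydroxy.

The nearest evidence is the step of no change at the digits printed from compound 2 to compound 3 (within the scatter), which puts 4-(ethoxycarbonyl)butoxy in place of hydrogen on an aromatic carbon and stays within the scatter. The step of a 4.3-fold higher number from compound 1 to compound 2 (0.63 log units; beyond the scatter) is modest and concerns a different side chain, so it bears on this change only loosely. Among the compounds with values here, no measured compound carries the hydroxy group, which leaves its own contribution unknown.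

The expected step is a 1.2-fold lower number from compound 3 to compound 4 (0.08 log units; within the scatter), with no size beyond the scatter and no firm direction anticipated. For compound 4 the estimated value is 2500 nM, with an expected range from 900 nM to 7000 nM.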

Compound 4, half-maximal inhibitory concentration: 1000 nM
Beside the measured number, compound 4's estimate is 2.5-fold (0.40 log units) above it; the measured number falls inside the stated range.
By their numbers in this assay, from the lowest: compounds 1 and 4 (each within the scatter of the next); then compounds 2 and 3 (each within the scatter of the next).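

Within the data shown here, the hydroxy position turns out to matter in a way the earlier compounds did not reveal. In this assay, cutting the 4-(ethoxycarbonyl)butyl from the oxygen on the aromatic ring gives a 3.0-fold lower number from compound 3 to compound 4 (0.48 log units; beyond the scatter) and so separates hydroxy from the ester chain, while the same hydroxy in place of hydrogen gives a 3.0-fold lower number from compound 2 to compound 4 (0.48 log units; beyond the scatter) even though the ester chain and hydrogen had been level. Compound 4 also joins compound 1 on this read-out, with a 1.4-fold higher number from compound 1 to compound 4 (0.15 log units; within the scatter) and no separation between the small hydroxy and the 3-(dimethylamino)propyl on that oxygen, so a long basic-named chain is not the only substituent at this place that stands apart from hydrogen. Nothing in the available information accounts for any of these steps.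

The four compounds leave open whether the free hydroxy itself is what counts, since a methoxy on the same oxygen would separate the hydrogen on that oxygen from the oxygen alone. They also leave open how a carboxylic acid at the end of the chain, or a shorter or longer amine chain, would read in this assay against the ethyl ester and the dimethylamino chain.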